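A few compounds are considered here, and "the series" means these few. Any claim that something is new, unique, unknown or untested is made for them only; others in the source may bear on it.

The three measured compounds share one core and differ only in the group on the carbonyl carbon: compound 1 `CC(C(=O)N1CCN(c2ccc(C(=O)NCCC3CC3)nn2)CC1)(C(F)(F)F)C(F)(F)F`, compound 2 `O=C(NCCC1CC1)c1ccc(N2CCN(C(=O)/C=C\C(F)(F)F)CC2)nn1` and compound 3 `CC1CCCCC1C(=O)N1CCN(c2ccc(C(=O)NCCC3CC3)nn2)CC1`. In an assay on microsomes from liver (strain ICR) for inhibition of acyl-CoA desaturase 1 (Mus musculus), read by scintillation counting, with a stated time of 20 h (a lower number here means a stronger inhibitor, a higher number a weaker inhibitor), compound 1 gives 113 nM. Compound 2 reaches only a limit of this assay, > 10000 nM, as recorded in the limit of > 10000 nM in this assay, at which 1 of the 3 values shown sits. Compound 3 gives 680 nM in this assay, the highest of the two numbers; the steps that lead to it are a 6.0-fold higher number from compound 1 to compound 3 (0.78 log units; beyond the scatter) and an at least 14-fold lower number from compound 2 to compound 3 (1.16 log units; beyond the scatter). The unmeasured compound 4 `O=C(NCCC1CC1)c1ccc(N2CCN(C(=O)c3cnc(Cl)nc3C(F)(F)F)CC2)nn1` differs from compound 3 in one place: 2-chloro-4-(trifluoromethyl)pyrimidin-5-yl in place of 2-methylcyclohexyl on a carbonyl carbon. Both measured steps ending at compound 3 bear on this exchange, and they show that the group on this carbonyl carbon can move the number a long way in either direction. The 1,1-bis(trifluoromethyl)ethyl of compound 1 gave the lowest number, while the 3,3,3-trifluoroprop-1-en-1-yl of compound 2 gave only a limit. Among the compounds with values here, compound 4 brings a trifluoromethyl on an aromatic ring with a chlorine, which has no close precedent among the three. A modest step downward is expected, a 4.5-fold lower number from compound 3 to compound 4 (0.66 log units; beyond the scatter), though with wide uncertainty. Compound 4 is therefore estimated at about 150 nM, expected to fall between 30 nM and 800 nM.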

Compound 4, half-maximal inhibitory concentration: 321 nM
For compound 4 the middle estimate is 2.1-fold (0.33 log units) below the measured one; measured number inside the range.
By their numbers in this assay, from the lowest: compound 1; then compound 4; then compound 3. At a limit, above all of these: compound 2.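

In this assay, the 2-chloro-4-(trifluoromethyl)pyrimidin-5-yl shows that a six-membered aromatic ring can take this place on the carbonyl carbon, with a 2.1-fold lower number from compound 3 to compound 4 (0.33 log units; beyond the scatter), although the 1,1-bis(trifluoromethyl)ethyl group keeps the lowest number of the four, with a 2.8-fold higher number from compound 1 to compound 4 (0.45 log units; beyond the scatter). The presence of fluorine in the group does not by itself settle the outcome, as the two fluorine-bearing groups compared in an at least 31-fold lower number from compound 2 to compound 4 (1.49 log units; beyond the scatter) lie far apart. Compound 2 stands at a limit of the assay rather than at a number, so this step gives only a minimum size: the limit of > 10000 nM in this assay, at which 1 of the 4 values shown sits.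

The compounds shown do not separate the contributions of the chlorine, the trifluoromethyl and the ring nitrogens, so it stays open whether a plain phenyl, or a pyrimidin-5-yl carrying only one of these two substituents, would give a number close to that of compound 4. From the compounds shown here alone, it also stays open whether these steps would hold with a carboxylic acid or an amine on the group, or with a longer chain in place of the 2-methylcyclohexyl.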